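The source may report more compounds than this note shows. Statements on the series, on what has been measured and on what is new or still open speak of the compounds shown alone.

Measured compounds:
Compound 1, `Cc1cc(Cl)c(S(C)(=O)=O)cc1C(=O)N=C(N)N`, gives 25 nM in a functional assay for inhibition of sodium/hydrogen exchanger (Oryctolagus cuniculus); a lower number here means a stronger inhibitor, a higher number a weaker inhibitor.
Compound 2, `CCc1cc(Oc2cccnc2)c(S(C)(=O)=O)cc1C(=O)N=C(N)N`, gives 27 nM in this assay.

Compound 2 holds the highest of the two numbers recorded in this assay, but its nearest neighbour is compound 1, and the gap between the two numbers lies within the scatter of repeated measurements, so the two cannot be ordered against each other. Compound 1 and compound 2 differ in more than one place, so nothing about a single structural change can be read from them.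

Compound 3, `Cc1cc(Oc2cccnc2)c(S(C)(=O)=O)cc1C(=O)N=C(N)N`, has not yet been measured. It differs from compound 2 in one place only: hydrogen in place of methyl on a saturated chain carbon bound to an aromatic carbon; cut one bond further out, the same difference reads ethyl to methyl. Within the data shown here, no pair of measured compounds shows the effect of this change on its own, so the direction and size of the step can only be expected, not read off. A change this small, on a chain bound to an aromatic carbon, is expected to move the number little, if at all beyond the scatter: the expected step is a 1.1-fold lower number from compound 2 to compound 3 (0.03 log units; within the scatter). For compound 3 in this assay the estimate is 25 nM, in a range from 10 nM to 70 nM.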

Compound 3, half-maximal inhibitory concentration: 8.8 nM
Estimate against measurement, compound 3: 2.8-fold (0.45 log units) above; the measured number lies below the stated range.
By their numbers in this assay, from the lowest: compound 3; then compounds 1 and 2 (each within the scatter of the next).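

Shortening the ethyl to methyl, on a saturated chain carbon bound to an aromatic carbon, gives a 3.1-fold lower number from compound 2 to compound 3 (0.49 log units; beyond the scatter) in this assay, so even the loss of a single carbon at this place moves the result beyond the scatter. Among these compounds, putting (pyridin-3-yl)oxy in place of chloro on an aromatic carbon, with the methyl kept, gives a 2.8-fold lower number from compound 1 to compound 3 (0.45 log units; beyond the scatter), so this exchange also lowers the number when it is the only change. Read together, these steps show that the matching numbers of compound 1 and compound 2 concealed two separate changes that pull in opposite directions, though nothing available here explains why either change has its effect.

Going by these compounds, it remains open whether a longer chain such as propyl would raise the number further, and whether ethyl would have the same effect with chloro in place of (pyridin-3-yl)oxy. It is equally unknown whether the gain belongs to the pyridine ring in particular, which a phenoxy group at the same place would help to test.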